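Groups on the aromatic nitrogen: expectation for compound 4

The compounds below may be only part of what the source reports. "The series", "measured", "known", "first", "only" and "open" are said of these compounds alone.

Measured so far:
compound 1 `COCCn1nc(C(=O)N[C@H]2COc3ccccc3N(C)C2=S)nc1Cc1ccccc1`: 566 nM
compound 2 `CN1C(=S)[C@@H](NC(=O)c2nc(Cc3ccccc3)n(C3CCC3)n2)COc2ccccc21`: 181 nM
compound 3 `CN1C(=S)[C@@H](NC(=O)c2nc(Cc3ccccc3)n(CC3CCOCC3)n2)COc2ccccc21`: 6310 nM
compound 4 `CN1C(=S)[C@@H](NC(=O)c2nc(Cc3ccccc3)n(-c3ncccn3)n2)COc2ccccc21`: not yet measured

In a functional assay on HT-29 cells (Homo sapiens) for inhibition, read by luminescence and CellTiter-Glo, with a stated time of 24 h (on this read-out higher numbers stand for an effect only at larger amounts of compound and lower numbers for an effect already at smaller amounts), compound 1 gives 566 nM, the second highest of the three numbers; compound 2 lies below it, a 3.1-fold lower number from compound 1 to compound 2 (0.50 log units; beyond the scatter), and compound 3 lies above it, an 11-fold higher number from compound 1 to compound 3 (1.05 log units; beyond the scatter). Compound 4 carries pyrimidin-2-yl in place of 2-methoxyethyl on an aromatic nitrogen. Both earlier steps change the same group and bear on this one: a 3.1-fold lower number from compound 1 to compound 2 (0.50 log units; beyond the scatter) and an 11-fold higher number from compound 1 to compound 3 (1.05 log units; beyond the scatter), so this position tolerates modest gains and large losses alike. For the measured compounds named here, no measured compound places an aromatic ring directly on that nitrogen, so the direction is open; a step of modest size in this assay, in either direction, is expected. Compound 4 is estimated at 600 nM (range 120 nM to 3000 nM), which means an expected 1.1-fold higher number from compound 1 to compound 4 (0.03 log units; within the scatter).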

Compound 4, half-maximal effective concentration: 3970 nM
Compound 4: the middle estimate sits 6.6-fold (0.82 log units) below what was measured; measured number outside the range, above it.
By their numbers in this assay, from the lowest: compound 2; then compound 1; then compounds 4 and 3 (each within the scatter of the next).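

In this assay, pyrimidin-2-yl directly on the aromatic nitrogen does worse than 2-methoxyethyl (a 7.0-fold higher number from compound 1 to compound 4 (0.85 log units; beyond the scatter)). The gap to cyclobutyl is wider (a 22-fold higher number from compound 2 to compound 4 (1.34 log units; beyond the scatter)), while pyrimidin-2-yl and (oxan-4-yl)methyl are not separated (a 1.6-fold lower number from compound 3 to compound 4 (0.20 log units; within the scatter)), so an aromatic ring here gives no advantage over the poorest saturated group. Nothing available bears on the reason for this. Open, on these data alone, is whether a plain phenyl on this nitrogen behaves like pyrimidin-2-yl. Also open, as far as these compounds go, is how a small methyl or a chain ending in an amine would fare.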